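Adding a tert-butyl group to an inactive amino analogue

The source may hold more compounds than are shown below. What is called first, only, known or untested is meant among the compounds shown, and "the series" means these compounds.

Three measured compounds share a sugar-bearing core and differ in the group attached through the triple bond and in one ring substituent. Compound 1 `CCCC#Cc1cn([C@@H]2O[C@H](CO)[C@@H](O)[C@H](O)[C@H]2O)c(=O)[nH]c1=O` carries a butyl chain there; in a functional assay on CCRF-CEM cells (Homo sapiens) for cytotoxicity, with a stated time of 72 h (a lower number here means a stronger inhibitor, a higher number a weaker inhibitor), compound 1 gives 123000 nM. Compound 2 `O=c1nc(O)c(C#Cc2ccccc2)cn1[C@@H]1O[C@H](CO)[C@@H](O)[C@H](O)[C@H]1O` carries a phenyl ring instead, and in this assay compound 2 gives 5200 nM. Compound 3 `Nc1nc(=O)n([C@@H]2O[C@H](CO)[C@@H](O)[C@H](O)[C@H]2O)cc1C#Cc1ccccc1` keeps the phenyl ring but has amino in place of hydroxy on an aromatic carbon. For compound 3 this assay reports only a limit, > 250000 nM, so compound 3 stands at the weak end of the set. Going by the values given here, the step of an at least 48-fold higher number from compound 2 to compound 3 (1.68 log units; beyond the scatter) is the only single-place change measured, and it bears on the core, not on the phenyl ring.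

Compound 4 `CC(C)(C)c1ccc(C#Cc2cn([C@@H]3O[C@H](CO)[C@@H](O)[C@H](O)[C@H]3O)c(=O)nc2N)cc1` differs from compound 3 by tert-butyl in place of hydrogen on an aromatic carbon. Among the compounds with values here, no measured step touches the phenyl ring, so nothing in the data sets the size of this change. Since compound 3 sits at the limit of > 250000 nM in this assay, at which 1 of the 3 values shown sits, the step from compound 3 to compound 4 is expected to be an at least 1.3-fold lower number from compound 3 to compound 4 (0.14 log units; that floor lies within the scatter), most likely staying within the scatter. In this assay compound 4 is therefore estimated at 180000 nM, with a range from 40000 nM to 600000 nM.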

Compound 4, half-maximal inhibitory concentration: > 250000 nM
Compound 4: no number, only a limit (the forecaster's own chance of this, stated with the estimate: 50%); middle value at least 1.3-fold (0.14 log units) away from the limit.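

Compound 3 and compound 4 both stand only at a limit, so the step between them cannot be read: the limit of > 250000 nM in this assay, at which 2 of the 4 values shown sit.

The compounds shown leave open how far tert-butyl in place of hydrogen on the phenyl ring moves the number in this assay, whether with the amino group on the shared core or with the hydroxy group of compound 2.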